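A few compounds are considered here, and "the series" means these few. Any claim that something is new, unique, unknown or untested is made for them only; others in the source may bear on it.

Working notes on a small set of ester-bearing compounds examined in an ADME assay on HepG2 cells (Homo sapiens) for cytotoxicity, read by luminescence, with a stated time of 72 h; a higher number here means that more compound is needed for the effect, a lower number that less compound is needed.

Compound 1 `CCOC(=O)c1c(-c2cccc(OC)c2)[nH]c2cc(F)cc(F)c2c1=O` is the methoxy member of the first core. In this assay compound 1 gives > 21500 nM, which is a limit of the assay and not a number. Compound 2 `CCOC(=O)c1c(-c2cccc(Oc3ccccc3)c2)[nH]c2cc(F)cc(F)c2c1=O` differs from compound 1 in one place, by phenyl in place of methyl on an oxygen on an aromatic ring. In this assay compound 2 gives > 21500 nM, again a limit. The step that the two limits leave unreadable from compound 1 to compound 2 therefore cannot be read, since both ends sit at a limit. Compound 3 `CCOC(=O)c1c(-c2cccc(OC)c2)[nH]c2cc(Cl)c(OC)cc2c1=O` carries the methoxy group on a second core; the difference between the core of compound 1 and the core of compound 3 is not broken down here. In this assay compound 3 gives > 21500 nM, also a limit. The whole picture so far is the limit of > 21500 nM in this assay, at which 3 of the 3 values shown sit.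

Compound 4 `CCOC(=O)c1c(-c2cccc(Oc3ccccc3)c2)[nH]c2cc(Cl)c(OC)cc2c1=O` has not been measured. It stands to compound 3 as compound 2 stands to compound 1, by phenyl in place of methyl on an oxygen on an aromatic ring. The place of the change is described word for word the same in both pairs, so it is the same change, phenyl in place of methyl on an oxygen on an aromatic ring, made on the second core. Within the set nothing yet distinguishes any member from the others, as every value shown is a limit. The expected step is a step that the limit leaves unreadable from compound 3 to compound 4, resting on (the limit of > 21500 nM in this assay, at which 3 of the 3 values shown sit). Compound 4 is expected to give 30000 nM, with the likely range from 12000 nM to 100000 nM.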

Compound 4, half-maximal effective concentration: > 21500 nM
Compound 4: a limit, no number; the forecaster's own chance of this, stated with the estimate: 85%; the middle value does not contradict the limit.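

In this assay compound 4 gives > 21500 nM, a limit of the assay and not a number. With compound 3 also at a limit, no step from methoxy to phenoxy can be read between compound 3 and compound 4, and the set stays flat: the limit of > 21500 nM in this assay, at which 4 of the 4 values shown sit.

The compounds shown leave open where, on either core, a measurable half-maximal effective concentration would lie in this assay.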